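This account rests on a few compounds, and the source may have more. Where it says the series, first, only, none or still open, it means among the compounds named here.

Among the compounds with values here, in a physicochemical assay for lipophilicity (on this read-out higher numbers stand for higher lipophilicity and lower numbers for lower lipophilicity), compound 2 `COc1c(OC)c(OC(=O)C(C)(C)C)c2c(OC)cccc2c1OC(=O)C(C)(C)C` gives 5.6, the lower of the two numbers so far, while compound 1 `COc1c(OC)c(OC(=O)C(C)(C)C)c2c(Cl)cccc2c1OC(=O)C(C)(C)C` gives 6.1. Compound 3 `COc1c(OC)c(OC(=O)C(C)(C)C)c2c(C)cccc2c1OC(=O)C(C)(C)C` is still unmeasured. It differs from compound 2 by methyl in place of methoxy on an aromatic carbon. Within the data shown here, the only measured step on that aromatic carbon is a number 0.50 log units lower from compound 1 to compound 2 (beyond the scatter), a modest one for methoxy in place of chloro. With methoxy leaving in turn, a rise of somewhat smaller size is expected, a number 0.30 log units higher from compound 2 to compound 3 (within the scatter). Compound 3 is estimated at 5.9, with an expected range from 5.6 to 6.3.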

Compound 3, partition coefficient: 6.1
Compound 3: the middle estimate sits 0.20 log units below what was measured; the measured number falls inside the stated range.
By their numbers in this assay, from the lowest: compound 2; then compounds 1 and 3 (each within the scatter of the next).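

In this assay, methyl in place of methoxy on this aromatic carbon gives a number 0.50 log units higher from compound 2 to compound 3 (beyond the scatter) and so reaches the same size as the earlier step, in the opposite direction. Methyl in place of chloro gives no change at the digits printed from compound 1 to compound 3 (within the scatter) and leaves those two groups indistinguishable here. Among the three groups, only the methoxy of compound 2 stands apart from both others. As far as these compounds go, how an amine, a hydroxyl group or a longer chain would read on this aromatic carbon remains open. Nothing available explains why methoxy stands apart.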